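A few compounds are considered here, and "the series" means these few. Any claim that something is new, unique, unknown or untested is made for them only; others in the source may bear on it.

Values measured in a functional assay on DU-145 cells (Homo sapiens) for antiproliferative activity, read by propidium iodide staining, with a stated time of 96 h; on this read-out lower numbers stand for stronger inhibition and higher numbers for weaker inhibition:
- compound 1 `CC(O)(CSc1cccc(S(F)(F)(F)(F)F)c1)C(=O)Nc1cccc(S(F)(F)(F)(F)F)c1`: 30300 nM
- compound 2 `CC(O)(COc1cccc(C(F)(F)F)c1)C(=O)Nc1cccc(S(F)(F)(F)(F)F)c1`: 31700 nM
- compound 3 `CC(O)(CS(=O)(=O)c1ccc(S(F)(F)(F)(F)F)cc1)C(=O)Nc1cccc(S(F)(F)(F)(F)F)c1`: 17400 nM

The value of compound 3, 17400 nM, lies within the usual scatter of the values of both compound 1 and compound 2, so these three cannot be told apart on these numbers. Compound 4 `CC(O)(CS(=O)(=O)c1ccc(OC(F)(F)F)cc1)C(=O)Nc1cccc(S(F)(F)(F)(F)F)c1` keeps the rest of compound 3 and places trifluoromethoxy on an aromatic carbon, para to a large group: a group of 5 heavy atoms (1 carbon, 1 oxygen, 3 fluorine; no ring) in place of a group of 6 heavy atoms (5 fluorine, 1 sulfur; no ring), on an aromatic carbon. For the measured compounds named here, no measured pair shows this swap directly. Compound 3, at 17400 nM, is the closest measured structure, so no step beyond the scatter is expected in this assay. The expected change is a 1.3-fold higher number from compound 3 to compound 4 (0.10 log units; within the scatter). For compound 4 the estimate is 22000 nM, with an expected range from 10000 nM to 45000 nM.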

Compound 4, half-maximal inhibitory concentration: 35600 nM
Beside the measured number, compound 4's estimate is 1.6-fold (0.21 log units) below it; the range from low to high includes it.
By their numbers in this assay, from the lowest: compounds 3, 1, 2 and 4 (each within the scatter of the next, the first and the last beyond it).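

In this assay, trifluoromethoxy in place of the group of 5 fluorine and 1 sulfur, on an aromatic carbon para to a large group, gives a 2.0-fold higher number from compound 3 to compound 4 (0.31 log units; beyond the scatter) and so provides the only readable step among these compounds. It is modest, but it shows that this swap at this position can move the number beyond the usual scatter. Nothing measured here explains the step.

On these data alone, whether an amine or a methyl group at this position would give a lower or a higher number stays open. So does whether the same swap would give a similar step on a different core.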